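The source may report more compounds than this note shows. Statements on the series, on what has been measured and on what is new or still open speak of the compounds shown alone.

In an ADME assay on Huh7.5.1 cells (Homo sapiens) for cytotoxicity, read by ATP content, with a stated time of 48 h (a lower number here means that less compound is tolerated, a higher number that more compound is tolerated), compound 1 `Cc1oc(-c2ccc(Cl)c(Cl)c2)nc1CN1CCC(C(=O)NCCCN2C[C@H](C)C[C@H](C)C2)CC1` gives 3170 nM and compound 2 `Cc1cccc(-c2nc(CN3CCC(C(=O)NCCCN4C[C@H](C)C[C@H](C)C4)CC3)c(C)o2)c1` gives 16500 nM as the higher of the two numbers. Next is compound 3 `CCc1ccccc1-c1nc(CN2CCC(C(=O)NCCCN3C[C@H](C)C[C@H](C)C3)CC2)c(C)o1`, where the change on the aromatic carbon is 2-ethylphenyl in place of 3-methylphenyl on an aromatic carbon and the rest of the structure stays as in compound 2. For the measured compounds named here, the only measured step at this carbon is a 5.2-fold higher number from compound 1 to compound 2 (0.72 log units; beyond the scatter) on losing the 3,4-dichlorophenyl group. Since compound 2 at 16500 nM already lacks that group as compound 3 does, a much smaller move in this assay is expected, with no firm direction and probably none beyond the scatter. The expected step is a 1.3-fold lower number from compound 2 to compound 3 (0.10 log units; within the scatter) in this estimate. For compound 3 the estimated value is 13000 nM within a range of 5500 nM to 30000 nM as the working expectation.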

Compound 3, half-maximal cytotoxic concentration: 9320 nM
Compound 3: the middle estimate sits 1.4-fold (0.14 log units) above what was measured, within the range that was stated.
By their numbers in this assay, from the lowest: compound 1; then compounds 3 and 2 (each within the scatter of the next).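

In this assay the swap to 2-ethylphenyl gives a 1.8-fold lower number from compound 2 to compound 3 (0.25 log units; within the scatter) here, so 3-methylphenyl and 2-ethylphenyl cannot be told apart at this aromatic carbon. Measured against 3,4-dichlorophenyl, 2-ethylphenyl gives a 2.9-fold higher number from compound 1 to compound 3 (0.47 log units; beyond the scatter) here, so compounds 2 and 3 both stand clear of compound 1, and the step from compound 1 is no longer tied to 3-methylphenyl alone. No measurement at hand explains either step.

As far as these compounds go, compound 3 alters both the alkyl chain and its place on the phenyl ring, and the share of each stays open. Also open, from the compounds shown here alone, is how this assay reads with an amine or a carboxylic acid on that phenyl ring.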